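Oxan-4-yl to 1-methyl-2-oxopiperidin-4-yl on the shared core

The compounds below may be only part of what the source reports. "The series", "measured", "known", "first", "only" and "open" are said of these compounds alone.

Three compounds carry a measurement in an assay on HEK293 cells for inhibition of acid ceramidase (Homo sapiens), read by fluorescence, with stated times of 10 min and 3 h; on this read-out higher numbers stand for weaker inhibition and lower numbers for stronger inhibition. Compound 1 `CC(C)CNC(=O)n1c(=O)oc2c(C3CCN(C)CC3)cccc21` gives 535 nM in this assay, and compound 2 `CC(C)CNC(=O)n1c(=O)oc2cc(C3CCCCN3C)ccc21` gives 1010 nM. Compound 3 `O=C(NCCCCc1ccccc1)n1c(=O)oc2cc(C3CCOCC3)ccc21` gives 68 nM, the lowest of the three numbers; its gap to compound 1 and its gap to compound 2 both lie beyond the usual scatter, so compound 3 stands as the strongest inhibitor of the set so far. No pair among these three differs in only one place, so no single step has been isolated.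

Compound 4 `CN1CCC(c2ccc3c(c2)oc(=O)n3C(=O)NCCCCc2ccccc2)CC1=O` differs from compound 3 in one place: 1-methyl-2-oxopiperidin-4-yl in place of oxan-4-yl on an aromatic carbon. For the measured compounds named here, no measured pair shows this exchange, so its size is not anchored by data. Compound 1 and compound 2, which both carry a ring with a nitrogen hetero atom on the core, sit well above compound 3, but they also differ in the amide chain, so that comparison does not isolate the ring. A small step is expected, leaning toward weaker inhibition, possibly inside the scatter, so that compound 4 is estimated at 120 nM with a range from 40 nM to 400 nM, meaning an expected step of a 1.8-fold higher number from compound 3 to compound 4 (0.25 log units; within the scatter).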

Compound 4, half-maximal inhibitory concentration: 105 nM
Compound 4: middle estimate off by 1.1-fold (0.06 log units), on the high side, and the stated range covers the measured number.
By their numbers in this assay, from the lowest: compounds 3 and 4 (each within the scatter of the next); then compounds 1 and 2 (each within the scatter of the next).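

In this assay, for the compounds shown here, the first single-place step is a 1.5-fold higher number from compound 3 to compound 4 (0.19 log units; within the scatter), which lies within the scatter for 1-methyl-2-oxopiperidin-4-yl in place of oxan-4-yl on this aromatic carbon. With the amide chain of compound 3 held constant, this position accepts a ring of 8 heavy atoms, including a ring nitrogen and a carbonyl, in place of one of 6 heavy atoms, with no change beyond the scatter. No supporting data bear on the reason for this result.

Going by these compounds, it remains open whether a morpholin-4-yl ring, a carboxylic acid or a primary amine at this position would also stay within the scatter of compound 3. On these data alone, it is also open whether the same exchange would give a step of similar size with the amide chain of compound 1.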